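Chloro Substitution in a Thiazolyl Ketone Series

The source may hold more compounds than are shown below. What is called first, only, known or untested is meant among the compounds shown, and "the series" means these compounds.

Measured so far:
compound 1, `Cc1nc(-c2ccccc2)sc1C(=O)CSc1nc(N)c(C#N)c(-c2ccc(Cl)cc2)n1`, 44.3%
compound 2, `Cc1nc(-c2ccccc2)sc1C(=O)CSc1nc(-c2cccc(Cl)c2)c(C#N)c(=O)[nH]1`, 50.6%
compound 3, `Cc1nc(-c2ccccc2)sc1C(=O)CSc1nc(-c2ccccc2)c(C#N)c(=O)[nH]1`, 77.5%

All three were run in a functional assay on U-87MG ATCC cells for antiproliferative activity against U-87 MG (Homo sapiens), read by MTT assay, with a stated time of 48 h, tested at 50 uM; a higher number here means a weaker effect of the compound at the concentration tested, a lower number a stronger effect. In this assay compound 3 gives 77.5%, compound 2 gives 50.6% and compound 1 gives 44.3%; the values of compound 1 and compound 2 lie within the scatter of each other. The step of a number 26.9 percentage points lower from compound 3 to compound 2 (beyond the scatter) belongs to the change (chloro in place of hydrogen on an aromatic carbon), where the chloro sits meta to a large group. The difference between the core of compound 1 and the core of compound 3 is not broken down here.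

Compound 4, `Cc1nc(-c2ccc(Cl)cc2)sc1C(=O)CSc1nc(N)c(C#N)c(-c2ccc(Cl)cc2)n1`, is not yet measured. It differs from compound 1 by chloro in place of hydrogen on an aromatic carbon, the chloro now para to a large group, so this is the same kind of change rather than the same one. A smaller step than a number 26.9 percentage points lower from compound 3 to compound 2 (beyond the scatter) is expected, since compound 1 already gives 44.3% and the other ring differs. The expected step is a number 8.3 percentage points lower from compound 1 to compound 4 (within the scatter). Compound 4 is estimated at 36%, between 20% and 55%.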

Compound 4, a percentage reported as activity, at one concentration (the size of the read-out at that concentration, not a potency): 15.5%
The estimate for compound 4 lay 20.5 percentage points above the measured number, and the stated range ends above it.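

In this assay the chloro change gives a number 28.8 percentage points lower from compound 1 to compound 4 (beyond the scatter), and its size holds across the two cores: the same change on two cores in this assay, a number 26.9 percentage points lower (beyond the scatter) from compound 3 to compound 2 and a number 28.8 percentage points lower (beyond the scatter) from compound 1 to compound 4, 1.9 percentage points apart, within the scatter of two such steps In these two pairs, then, chloro in place of hydrogen on an aromatic carbon lowers the number by a similar amount, although it stands on a different ring in each pair. Two pairs do not establish that the change carries to other cores, nor do they separate the contribution of the core from that of the place of the chloro.

The compounds shown leave open whether the step is specific to chloro or also appears with fluoro, methoxy or an amine in the same place. Also open, on these data alone, is whether the step holds on the core of compound 3 when the chloro sits as in the 4-chlorophenyl of compound 4.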